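The source may hold more compounds than are shown below. What is called first, only, known or untested is meant among the compounds shown, and "the series" means these compounds.

Of the compounds shown here, two built on one shared core have so far been tested in a toxicity assay on HepG2 cells (Homo sapiens) for inhibition, read by CellTiter-Glo, with a stated time of 48 h; on this read-out higher numbers stand for weaker inhibition and lower numbers for stronger inhibition. Compound 1, `COc1ccc2nc(C)cc(OCC(=O)Nc3cc(C)ccc3C)c2c1`, carries a 2,5-dimethylphenyl on an amide-type nitrogen. In this assay compound 1 gives > 100000 nM, which is a limit of the assay rather than a number. Compound 2, `COc1ccc2nc(C)cc(OCC(=O)Nc3cc(OC)c(Cl)cc3OC)c2c1`, carries a different group on that amide-type nitrogen. In this assay compound 2 gives > 100000 nM, again a limit of the assay and not a number. Compound 1 therefore stands where the whole small set stands, as summed up by the limit of > 100000 nM in this assay, at which 2 of the 2 values shown sit. For the measured compounds named here, no step between two measured compounds is known, so there is no measured change to lean on.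

The next compound is compound 3, `COc1ccc2nc(C)cc(OCC(=O)NNC(=O)c3ccncc3)c2c1`. Compared with compound 1 it differs as follows: ((pyridin-4-yl)carbonyl)amino in place of 2,5-dimethylphenyl on an amide-type nitrogen. Because both measured compounds sit at the limit described in the limit of > 100000 nM in this assay, at which 2 of the 2 values shown sit, compound 3 is expected to behave alike. In this assay compound 3 is expected to give about 100000 nM, within a range from 30000 nM to 300000 nM. The expected step of a number no higher from compound 1 to compound 3 (the limit leaves the size open) is none beyond the usual scatter.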

Compound 3, half-maximal inhibitory concentration: > 100000 nM
Compound 3 gave a limit, no number; the forecaster's own chance of this, stated with the estimate: 80%; the middle value lies on the limit itself.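

No step can be read from compound 1 to compound 3, since the values of both compounds in this assay are limits of the assay and not numbers: the limit of > 100000 nM in this assay, at which 3 of the 3 values shown sit.

The compounds shown leave open at what concentration any of them would inhibit these cells, and whether the group on the amide-type nitrogen makes any difference.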